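This account rests on a few compounds, and the source may have more. Where it says the series, first, only, none or still open, it means among the compounds named here.

Three compounds sharing one core have been run in an ADME assay on BJ cells (Homo sapiens) for antiproliferative activity, with a stated time of 72 h; on this read-out higher numbers stand for an effect only at larger amounts of compound and lower numbers for an effect already at smaller amounts. Compound 1 `COc1ccc(-c2cc(=O)c3c(OC)cc(OC)cc3n2S(=O)(=O)c2cccc([N+](=O)[O-])c2)cc1` carries a 3-nitrophenyl on the sulfonyl sulfur, and in this assay compound 1 reaches only a limit, > 39600 nM. Compound 2 `COc1ccc(-c2cc(=O)c3c(OC)cc(OC)cc3n2S(=O)(=O)c2ccc(C#N)cc2)cc1` has a 4-cyanophenyl in that place, and compound 2 also returns only a limit, > 17200 nM. Compound 3 `COc1ccc(-c2cc(=O)c3c(OC)cc(OC)cc3n2S(=O)(=O)c2ccc(F)cc2)cc1` has a 4-fluorophenyl there, and compound 3 likewise gives only a limit, > 65500 nM. Because every value is a limit, as the limit of > 17200 nM in this assay, at which 1 of the 3 values shown sits, the limit of > 39600 nM in this assay, at which 1 of the 3 values shown sits, and the limit of > 65500 nM in this assay, at which 1 of the 3 values shown sits, show, compound 3 cannot be placed above or below its two neighbours; the three simply sit at the edge of what this assay can report.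

The same holds for the measured steps: a step that the two limits leave unreadable from compound 1 to compound 2, a step that the two limits leave unreadable from compound 1 to compound 3 and a step that the two limits leave unreadable from compound 2 to compound 3 are all unreadable in size, since each starts and ends at a limit.

Compound 4 `COc1ccc(-c2cc(=O)c3c(OC)cc(OC)cc3n2S(=O)(=O)c2cc(F)c(F)c(F)c2)cc1` is the next member. The change from compound 3 is 3,4,5-trifluorophenyl in place of 4-fluorophenyl on a sulfonyl sulfur. For the measured compounds named here, no measured step reads out a size for changes on this phenyl, so the expectation for compound 4 rests on the three limits alone. Compound 4 is therefore expected to stay at a limit as well, with an estimated step of an at least 1.0-fold lower number from compound 3 to compound 4 (0.03 log units; that floor lies within the scatter) that lies within the scatter. The estimate for compound 4 in this assay is 60000 nM, expected to fall between 20000 nM and 200000 nM.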

Compound 4, half-maximal effective concentration: > 65500 nM
Compound 4: a limit, no number; the forecaster's own chance of this, stated with the estimate: 85%; at least 1.0-fold (0.03 log units) between middle value and limit.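

In this assay compound 4 also returns only a limit, so its steps from compound 1, compound 2 and compound 3 cannot be read in size. The compounds shown leave open whether any of these groups on the sulfonyl sulfur gives a readable effect in this assay and how large that effect would be.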